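Amide aryl swap and Vero cytotoxicity in the series

The source may hold more compounds than are shown below. What is called first, only, known or untested is meant among the compounds shown, and "the series" means these compounds.

Going by the values given here, compound 2 `COc1ccc(-n2c(SC(C)C(=O)Nc3nc(C)c(Cl)cc3Cl)nc3ccccc32)cc1` is the one compound of the pair with a number in an ADME assay on Vero cells (Chlorocebus sabaeus) for cytotoxicity, read by MTT assay, with a stated time of 24 h (on this read-out lower numbers stand for higher toxicity in this test and higher numbers for lower toxicity in this test), where compound 2 gives 7250 nM. Compound 1 `COc1ccc(Cn2c(SC(C)C(=O)Nc3ccc(C)cc3Cl)nc3ccccc32)cc1` reaches only a limit in this assay, > 75000 nM, so its reading is a limit and not a number (the limit of > 75000 nM in this assay, at which 1 of the 2 values shown sits). Compound 3 `COc1ccc(-n2c(SC(C)C(=O)Nc3ccc(C)cc3Cl)nc3ccccc32)cc1` is not yet measured; it follows from compound 2 by the change (2-chloro-4-methylphenyl in place of 3,5-dichloro-6-methylpyridin-2-yl on an amide-type nitrogen). Among the compounds with values here, compound 1 also carries the (2-chloro-4-methylphenyl)amino group, and its reading sits at the limit, whereas compound 2 gives a number; no step between compound 1 and compound 3 is recorded, so only those two readings speak. For compound 3 the expected move in this assay is upward, toward lower toxicity, by about a 5.5-fold higher number from compound 2 to compound 3 (0.74 log units; beyond the scatter). Compound 3 is therefore estimated at 40000 nM in this assay, within 12000 nM to 100000 nM, with a fair chance that only a limit is reported.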

Compound 3, half-maximal cytotoxic concentration: > 75000 nM
Compound 3: only a limit was reported; the forecaster's own chance of this, stated with the estimate: 40%; middle value at least 1.8-fold (0.27 log units) from the limit.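

In this assay, 2-chloro-4-methylphenyl in place of 3,5-dichloro-6-methylpyridin-2-yl on the amide-type nitrogen gives an at least 10-fold higher number from compound 2 to compound 3 (1.01 log units; beyond the scatter). Going by these compounds alone, this is the first reading of this change with the rest of the molecule held constant, as compound 1 and compound 2 differ in more than one place. Compound 3 gives a limit and not a number, which leaves the full size of the step unknown: the limit of > 75000 nM in this assay, at which 2 of the 3 values shown sit.

The step between compound 1 and compound 3 cannot be read, as both readings are limits. Also open, going by these compounds, is which part of the 3,5-dichloro-6-methylpyridin-2-yl group goes with the lower number of compound 2, and how an unsubstituted phenyl or an unsubstituted pyridinyl group on the same amide-type nitrogen would read.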